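Trimming the chain from compound 3 to compound 4

The source may hold more compounds than are shown below. What is called first, only, known or untested is meant among the compounds shown, and "the series" means these compounds.

Values so far in a functional assay, read by fluorescence and spectrophotometry, with a stated time of 1 h (on this read-out lower numbers stand for an effect already at smaller amounts and higher numbers for an effect only at larger amounts of compound), are:
compound 1 `O=S(=O)(/C=C/c1ccc(O)c(O)c1)CCC1CCCCC1` gives 9800 nM
compound 2 `O=S(=O)(/C=C/c1ccc(O)c(O)c1)CCC1CCCC1` gives 6800 nM
compound 3 `O=S(=O)(/C=C/c1ccc(O)c(O)c1)CCCC1CCCC1` gives 6300 nM

Compound 3 is not separated from the other two measured compounds, as a 1.1-fold lower number from compound 2 to compound 3 (0.03 log units; within the scatter) and a 1.6-fold lower number from compound 1 to compound 3 (0.19 log units; within the scatter) both show. The next compound, compound 4 `O=S(=O)(/C=C/c1ccc(O)c(O)c1)CC1CCCC1`, carries cyclopentyl in place of 2-cyclopentylethyl on a saturated chain carbon bound to a sulfonyl sulfur, and the counted difference is cyclopentyl in place of 2-cyclopentylethyl on a saturated chain carbon bound to a sulfonyl sulfur here.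

The closest measured change is a 1.1-fold lower number from compound 2 to compound 3 (0.03 log units; within the scatter), with cyclopentylmethyl in place of cyclopentyl. The remaining step, a 1.4-fold lower number from compound 1 to compound 2 (0.16 log units; within the scatter), also stays small. Among the measured compounds shown here, no measured compound has cyclopentyl on a saturated chain carbon bound to a sulfonyl sulfur, so this reading is an extrapolation. No step beyond the scatter is expected in this assay, in either direction. The estimated change is a 1.2-fold higher number from compound 3 to compound 4 (0.08 log units; within the scatter) overall. For compound 4 the estimated value is 7500 nM, with an expected range from 3500 nM to 16000 nM for repeated measurements.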

Compound 4, half-maximal effective concentration: 9400 nM
Compound 4: middle estimate off by 1.3-fold (0.10 log units), on the low side; the measured number falls inside the stated range.
By their numbers in this assay, from the lowest: compounds 3, 2, 4 and 1 (each within the scatter of the next).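

In this assay, the new compound extends the span of carbon groups tolerated at this position on a saturated chain carbon bound to a sulfonyl sulfur: cyclopentyl in place of 2-cyclopentylethyl (a 1.5-fold higher number from compound 3 to compound 4 (0.17 log units; within the scatter)) and cyclopentyl in place of cyclopentylmethyl (a 1.4-fold higher number from compound 2 to compound 4 (0.14 log units; within the scatter)) both stay within the scatter. Cyclopentyl in place of cyclohexylmethyl (a 1.0-fold lower number from compound 1 to compound 4 (0.02 log units; within the scatter)) also stays within the scatter, so none of these steps separates the compounds, and the size of the carbon group shows no effect on the read-out in this set. No available evidence bears on why these groups read alike.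

All four compounds carry only saturated carbon groups here. As far as these compounds go, whether an amine, a carboxylic acid or a phenyl ring at this position would give a step beyond the scatter in this assay remains open.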